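The source may report more compounds than this note shows. Statements on the series, on what has been measured and on what is new or still open speak of the compounds shown alone.

Measured compounds:
- compound 1, `Cc1ncc(CO)c2c(Nc3ccccn3)c(NC(C)C)oc12`: "not active" (no number reported)
- compound 2, `Cc1ncc(CO)c2c(Nc3ccccn3)c(NCCC(=O)OC(C)(C)C)oc12`: 7640 nM

Among the compounds with values here, in a functional assay on HEK293 cells for agonist activity at Toll-like receptor 8 (Homo sapiens), read by reporter gene assay (a higher number here means that more compound is needed for the effect, a lower number that less compound is needed), compound 2 gives 7640 nM, the only number in this small set. Compound 1 was reported as "not active" (no number reported), with no number attached. Compound 3, `Cc1ncc(CO)c2c(Nc3ccccn3)c(NC(C)(C)C)oc12`, has not been measured. It differs from compound 2 in one place: tert-butyl in place of 2-(tert-butoxycarbonyl)ethyl on a nitrogen on an aromatic ring. Compound 1, which likewise lacks the 2-(tert-butoxycarbonyl)ethyl group on that nitrogen, gave no measurable activity, so the removal of this group in compound 3 is expected to push the number upward, toward weaker agonism, by more than the usual scatter, and there is a real chance that compound 3 likewise returns no number at all. The expected step from compound 2 to compound 3 is a 3.3-fold higher number from compound 2 to compound 3 (0.51 log units; beyond the scatter). Compound 3 is therefore estimated at 25000 nM in this assay, within a range from 7000 nM to 90000 nM.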

Compound 3, half-maximal effective concentration: "not active" (no number reported)
Compound 3: no number reported, and the estimate cannot be compared.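

Within the data shown here, compound 3, like compound 1, came back without a number, so no step from compound 2 to compound 3 can be read. No measurement shown bears on this result. The compounds shown leave open which part of the 2-(tert-butoxycarbonyl)ethyl group goes with the measurable activity of compound 2 in this assay.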